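From Phenoxy to Dimethylamino: One Substitution, One Expectation

The compounds below may be only part of what the source reports. "The series", "measured", "known", "first", "only" and "open" are said of these compounds alone.

Of the compounds shown here, two have been measured in a functional assay on MDA-MB-231 cells (Homo sapiens) for inhibition, read by sulforhodamine B assay, with a stated time of 48 h; a lower number here means a stronger inhibitor of growth, a higher number a weaker inhibitor of growth. Compound 1, `COc1cc(C)cc(-c2c(-c3ccnc(-c4ccc(C(C)=O)cc4)c3)cnn2CC#N)c1`, gives only a limit in this assay, > 100000 nM, rather than a number. Compound 2, `Cc1cc(O)cc(-c2nn(CC#N)cc2-c2ccnc(-c3ccc(Oc4ccccc4)cc3)c2)c1`, gives 7330 nM in this assay. Among the compounds with values here, of the values shown, compound 2 therefore provides the only number. The other entry is the limit of > 100000 nM in this assay, at which 1 of the 2 values shown sits, and compound 1 sits at it.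

Compound 3, `Cc1cc(O)cc(-c2nn(CC#N)cc2-c2ccnc(-c3ccc(N(C)C)cc3)c2)c1`, has not been measured. It differs from compound 2 in one place: dimethylamino in place of phenoxy on an aromatic carbon, para to a large group. Within the data shown here, no pair of measured compounds differs in just this way, so the size of this step cannot be read from the data; a change of this kind could shift growth inhibition in either direction, or not beyond the usual scatter. On that basis compound 3 is expected to give about 11000 nM in this assay, with a likely range from 3000 nM to 45000 nM. The expected step is a 1.5-fold higher number from compound 2 to compound 3 (0.18 log units; within the scatter), leaning toward a modest weakening but not clearly beyond scatter.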

Compound 3, concentration for total growth inhibition: 22600 nM
The estimate for compound 3 lay 2.1-fold (0.31 log units) below the measured number, and the stated range covers the measured number.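

In this assay, placing dimethylamino instead of phenoxy on this aromatic carbon, para to a large group, gives a 3.1-fold higher number from compound 2 to compound 3 (0.49 log units; beyond the scatter), so growth inhibition in these cells does depend on what this carbon carries. Within the data shown here, the step is modest, but it is the first that can be read at this position, as no earlier pair of compounds differed in one place only. The change takes away a six-membered aromatic ring of carbon and brings in a group with fewer heavy atoms while the count of hydrogen-bond acceptors stays the same, and nothing measured here tells which part of this swap matters.

The compounds shown leave open how a morpholine ring, a primary amine or a carboxylic acid on this carbon would compare with compound 2 and compound 3. They also leave open whether the ring itself or the atom joining the group to the aromatic carbon counts for more, a question that a piperidine ring or a benzyl group at the same place could help to separate.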